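A few compounds are considered here, and "the series" means these few. Any claim that something is new, unique, unknown or untested is made for them only; others in the source may bear on it.

Measured compounds:
- compound 1 `Cc1cc(C(=O)Nc2ccc(N3CC[C@H](N4CCC[C@@H]4C)C3)cc2C)n[nH]1`: 4.7 nM
- compound 2 `Cc1cc(N2CC[C@H](N3CCC[C@@H]3C)C2)ccc1NC(=O)c1cc(C)n(C)n1`: 10.8 nM
- compound 3 `Cc1nc(N2CC[C@H](N3CCC[C@@H]3C)C2)ccc1NC(=O)c1ccccc1`: 3 nM

In an assay on CHO cells for displacement of a labelled ligand from histamine receptor H3 (Macaca mulatta), read by scintillation counting, with a stated time of 1 h (a lower number here means a stronger inhibitor, a higher number a weaker inhibitor), compound 3 gives 3 nM, the lowest of the three numbers. Compound 1 lies nearest, within the scatter of compound 3, so the two cannot be ranked; compound 2 lies furthest and its number is beyond the scatter from that of compound 3. Among the measured compounds shown here, the only step measured between neighbouring structures is a 2.3-fold higher number from compound 1 to compound 2 (0.36 log units; beyond the scatter), a change on an aromatic nitrogen of the amide's heteroaryl part.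

Compound 4 `Cc1nc(N2CC[C@H](N3CCC[C@@H]3C)C2)ccc1NC(=O)c1cccc2ccccc12` differs from compound 3 by naphthalen-1-yl in place of phenyl on a carbonyl carbon. For the measured compounds named here, no measured step touches the aryl group attached to the carbonyl, so the measured step from compound 1 to compound 2 does not bear on this change, and the expectation rests on the shared core and on the value of compound 3 alone. In this assay a step of about a 1.3-fold higher number from compound 3 to compound 4 (0.12 log units; within the scatter) is expected, that is, no change beyond the scatter, with a wide range to either side. Compound 4 is therefore estimated at 4 nM, between 1.2 nM and 15 nM.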

Compound 4, inhibition constant in the histamine receptor H3 assay: 4.2 nM
Compound 4: middle estimate off by 1.1-fold (0.02 log units), on the low side; measured number inside the range.
By their numbers in the histamine receptor H3 assay, from the lowest: compounds 3, 4 and 1 (each within the scatter of the next); then compound 2.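

In the histamine receptor H3 assay, the carbonyl carbon carries naphthalen-1-yl as well as phenyl, and the second six-membered aromatic ring of carbon only leaves the number within the scatter (a 1.4-fold higher number from compound 3 to compound 4 (0.15 log units; within the scatter)). Among the compounds shown here, this is the first measured step at this position, as the earlier step concerned an aromatic nitrogen of the amide's heteroaryl part. In a physicochemical assay for acid dissociation, the same replacement also stays within the scatter (no change at the digits printed from compound 3 to compound 4 (within the scatter)), with compound 3 at 9.9 and compound 4 at 9.9, and no evidence at hand accounts for either result.

The compounds shown leave open how this position responds to a non-aromatic group such as cyclohexyl, or to a phenyl carrying a carboxylic acid or an amine. They also leave open whether naphthalen-1-yl gives a similar result on the core of compound 1.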